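The source may hold more compounds than are shown below. What is called first, only, known or untested is meant among the compounds shown, and "the series" means these compounds.

In an in vitro ADME assay on microsomes from liver (Rattus norvegicus) for metabolic stability (a higher number here means faster removal of the compound, a lower number slower removal), compound 1 (`Cc1cc(C(=O)Nc2ccccc2)nn1Cc1cc(Cl)ccc1OCc1ccccc1`) gives 12 mL.min-1.g-1, and compound 2 (`Cc1cc(NC(=O)OC(C)(C)C)nn1Cc1cc(Cl)ccc1OCc1ccccc1`) gives 2.2 mL.min-1.g-1, the lower of the two numbers. Compound 3 (`Cc1cc(NC(=O)OCC(C)C)nn1Cc1cc(Cl)ccc1OCc1ccccc1`) has isobutyl in place of tert-butyl on an oxygen next to a carbonyl group. Within the data shown here, the only measured step is a 5.5-fold lower number from compound 1 to compound 2 (0.74 log units; beyond the scatter), which exchanged phenylcarbamoyl for (tert-butoxycarbonyl)amino. Among the measured compounds shown here, it therefore bears on the new change only indirectly, and no measured pair swaps tert-butyl for isobutyl. Since compound 3 has the same atoms as compound 2, joined differently, a smaller shift than that measured step is expected in this assay. The direction is uncertain, but with compound 2 lowest at 2.2 mL.min-1.g-1, a modest rise is the expectation. The expected step is a 1.6-fold higher number from compound 2 to compound 3 (0.20 log units; within the scatter). For compound 3 the estimated value is 3.5 mL.min-1.g-1, with an expected range of 1.5 mL.min-1.g-1 to 8.5 mL.min-1.g-1.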

Compound 3, intrinsic clearance in microsomes: 8.2 mL.min-1.g-1
For compound 3 the middle estimate is 2.3-fold (0.37 log units) below the measured one, and the stated range covers the measured number.
By their numbers in this assay, from the lowest: compound 2; then compounds 3 and 1 (each within the scatter of the next).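

In this assay, the group on the oxygen next to the carbonyl proves to matter in its own right: with the same atoms joined differently, isobutyl in place of tert-butyl gives a 3.7-fold higher number from compound 2 to compound 3 (0.57 log units; beyond the scatter) and so takes back most of what the earlier exchange had shown. Exchanging phenylcarbamoyl for (isobutoxycarbonyl)amino gives only a 1.5-fold lower number from compound 1 to compound 3 (0.17 log units; within the scatter) within this series, so the low number of compound 2 is tied to tert-butyl and not to the (alkoxycarbonyl)amino link alone. Nothing measured here explains the difference between these two chains.

From the compounds shown here alone, whether a longer chain such as n-butyl, or a cyclopropylmethyl group, on that oxygen would sit nearer compound 2 or compound 3 remains open. So does the effect of an amine nitrogen in place of that oxygen.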